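Benzylsulfanyl in place of hexylsulfanyl on a cyclopropylidene nucleoside core

This account rests on a few compounds, and the source may have more. Where it says the series, first, only, none or still open, it means among the compounds named here.

Compound 1 `C=CCOc1nc(N)nc2c1ncn2/C=C1/CC1(CO)CO`: in an ADME assay on Akata cells (Homo sapiens) for cytotoxicity, with a stated time of 7 days (on this read-out lower numbers stand for higher toxicity in this test and higher numbers for lower toxicity in this test), compound 1 gives > 20000 nM, a limit of the assay.
Compound 2 `COCCOc1nc(N)nc2c1ncn2/C=C1/CC1(CO)CO`: in this assay compound 2 gives > 20000 nM, a limit of the assay.
Compound 3 `CCCCCCSc1nc(N)nc2c1ncn2/C=C1/CC1(CO)CO`: in this assay compound 3 gives > 20000 nM, a limit of the assay.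

All three measured compounds share a core and differ only at one position on the aromatic ring. Compound 3 stands at the same place as the other two: its value is a limit, and (the limit of > 20000 nM in this assay, at which 3 of the 3 values shown sit). The step that the two limits leave unreadable from compound 1 to compound 2, the step that the two limits leave unreadable from compound 1 to compound 3 and the step that the two limits leave unreadable from compound 2 to compound 3 are all unreadable, since each sits between two limits.

Compound 4 `Nc1nc(SCc2ccccc2)c2ncn(/C=C3/CC3(CO)CO)c2n1` arises from compound 3 by the change (phenyl in place of pentyl on a saturated chain carbon bound to a sulfur). Within the data shown here, no measured step can be read for size, so the bearing of the measured steps on this change is only that every value so far sits at the limit. The expected step that the limit leaves unreadable from compound 3 to compound 4 is therefore set at none beyond the scatter, and compound 4 is expected to remain at the limit in this assay. The estimate for compound 4 is 30000 nM, with a range from 10000 nM to 100000 nM.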

Compound 4, half-maximal cytotoxic concentration: > 20000 nM
Compound 4 was reported as a limit (the forecaster's own chance of this, stated with the estimate: 80%); the middle value does not contradict the limit.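

In this assay compound 4 gives > 20000 nM, a limit of the assay. Among these compounds, no step joining compound 4 to compound 1, compound 2 or compound 3 can be read, since each lies between two limits: the limit of > 20000 nM in this assay, at which 4 of the 4 values shown sit. The compounds shown leave open whether changing the group on this aromatic carbon alters the read-out in this assay at all.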